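Adding propargylcarbamoyl to a small methyl amide

This account rests on a few compounds, and the source may have more. Where it says the series, first, only, none or still open, it means among the compounds named here.

Compound 1 `CCCC(=O)OCSc1ccccc1C(=O)N[C@@H]1CCC[C@H]1C(N)=O` gives 43.7 uM
Compound 2 `CCCC(=O)OCSc1ccccc1C(=O)N[C@@H]1CCC[C@@H]1C(N)=O` gives 90 uM
Compound 3 `CCCC(=O)OCSc1ccccc1C(=O)NC` gives 5.7 uM

These numbers come from an ADME assay on CEM-SS cells (Homo sapiens) for cytotoxicity, read by XTT assay, with a stated time of 6 days (a lower number here means that less compound is tolerated, a higher number that more compound is tolerated), and compound 3 at 5.7 uM has the lowest of them, beyond the scatter from both others. Compound 4 `C#CCNC(=O)CNC(=O)c1ccccc1SCOC(=O)CCC` keeps the core of compound 3 but carries propargylcarbamoyl in place of hydrogen on a saturated chain carbon bound to an amide-type nitrogen.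

Among the measured compounds shown here, two measured steps concern the group on that same nitrogen. Methyl in place of 2-carbamoylcyclopentyl gives a 7.7-fold lower number from compound 1 to compound 3 (0.88 log units; beyond the scatter) and also a 16-fold lower number from compound 2 to compound 3 (1.20 log units; beyond the scatter) on this scale. Read backwards, these two steps suggest that a group larger than methyl on that nitrogen raises the number, so compound 4 is expected to stand above compound 3 in this assay as well. The size of the rise is less certain. Compounds 1 and 2 themselves stand apart, with a 2.1-fold higher number from compound 1 to compound 2 (0.31 log units; beyond the scatter) due to the fact that compounds 1 and 2 differ only in the configuration as drawn and the new group in compound 4 has no ring. Only part of those measured steps is therefore expected to carry over. The expected step, smaller than both of them, is (a 3.5-fold higher number from compound 3 to compound 4 (0.55 log units; beyond the scatter)). Compound 4 is estimated at 20 uM (expected range 6 uM to 65 uM).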

Compound 4, half-maximal toxic concentration: 95.4 uM
Compound 4: middle estimate off by 4.8-fold (0.68 log units), on the low side, and the stated range ends below it.
By their numbers in this assay, from the lowest: compound 3; then compound 1; then compounds 2 and 4 (each within the scatter of the next).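

In this assay, adding propargylcarbamoyl on the saturated chain carbon bound to the amide-type nitrogen gives a 17-fold higher number from compound 3 to compound 4 (1.22 log units; beyond the scatter), so the rise seen with the larger groups on this nitrogen does not depend on the ring of compounds 1 and 2. Replacing 2-carbamoylcyclopentyl with the open (propargylcarbamoyl)methyl group gives a 1.1-fold higher number from compound 2 to compound 4 (0.03 log units; within the scatter) and also a 2.2-fold higher number from compound 1 to compound 4 (0.34 log units; beyond the scatter), which means that the chain matches one ring-bearing stereoisomer within the scatter and stands above the other beyond it. Among these four compounds, methyl gives the lowest number, and all three larger groups on this nitrogen give higher numbers.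

Nothing shown here explains why the open chain and the ring-bearing group of compound 2 fall within the scatter of each other. As far as these compounds go, it also remains open which part of the new group carries the rise, and a carbamoylmethyl group without the propargyl part, or a longer alkyl chain on the same nitrogen, would help separate the contribution of the amide from that of chain length.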